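Phenoxy removed twice in a cytotoxicity series

A few compounds are considered here, and "the series" means these few. Any claim that something is new, unique, unknown or untested is made for them only; others in the source may bear on it.

Compound 2 `Cc1ccc(C2CC(c3ccc(Oc4ccccc4)cc3)=NN2c2ccc(S(N)(=O)=O)cc2)cc1` and compound 1 `Cc1ccc(C2CC(c3ccccc3)=NN2c2ccc(S(N)(=O)=O)cc2)cc1` differ in one place: hydrogen in place of phenoxy on an aromatic carbon. In an ADME assay on BHK-21 cells (Mesocricetus auratus) for cytotoxicity, read by MTT assay, with a stated time of 72 h (a higher number here means that more compound is tolerated, a lower number that less compound is tolerated), compound 2 gives 8000 nM and compound 1 gives 7000 nM, so the step of a 1.1-fold lower number from compound 2 to compound 1 (0.06 log units; within the scatter). Compound 3 `Cc1ccccc1C1CC(c2ccc(Oc3ccccc3)cc2)=NN1c1ccc(S(N)(=O)=O)cc1` shares the core of compound 2 but differs in that (2-methylphenyl in place of 4-methylphenyl on a saturated ring carbon); in this assay compound 3 gives 7000 nM, and the step of a 1.1-fold lower number from compound 2 to compound 3 (0.06 log units; within the scatter). Compound 4 `Cc1ccccc1C1CC(c2ccccc2)=NN1c1ccc(S(N)(=O)=O)cc1` has not yet been measured. For the measured compounds named here, it arises from compound 3 by the same change as the one from compound 2 to compound 1: hydrogen in place of phenoxy on an aromatic carbon. Because the earlier step of a 1.1-fold lower number from compound 2 to compound 1 (0.06 log units; within the scatter) stayed within the scatter, the step from compound 3 to compound 4 is expected to be about as small, a 1.1-fold lower number from compound 3 to compound 4 (0.03 log units; within the scatter). Compound 4 is therefore estimated to give 6500 nM in this assay, within 3500 nM to 12000 nM.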

Compound 4, half-maximal cytotoxic concentration: 14000 nM
For compound 4 the middle estimate is 2.2-fold (0.33 log units) below the measured one; the whole stated range lies below it.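

In this assay, hydrogen in place of phenoxy on an aromatic carbon gives a 2.0-fold higher number from compound 3 to compound 4 (0.30 log units; within the scatter), and 2-methylphenyl in place of 4-methylphenyl on a saturated ring carbon gives a 2.0-fold higher number from compound 1 to compound 4 (0.30 log units; within the scatter). The phenoxy change cannot be told apart between the two cores, so in these compounds it carries over within the scatter: the same change on two cores in this assay, a 1.1-fold lower number (0.06 log units; within the scatter) from compound 2 to compound 1 and a 2.0-fold higher number (0.30 log units; within the scatter) from compound 3 to compound 4, 2.3-fold (0.36 log units) apart, within the scatter of two such steps The methylphenyl change reads the same way, although one pair of steps per change does not show that the steps are truly equal or that they would hold on any other core: the same change on two cores in this assay, a 1.1-fold lower number (0.06 log units; within the scatter) from compound 2 to compound 3 and a 2.0-fold higher number (0.30 log units; within the scatter) from compound 1 to compound 4, 2.3-fold (0.36 log units) apart, within the scatter of two such steps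

The compounds shown leave open how an amine or a carboxylic acid in place of phenoxy would read in this assay. They also leave open whether either change carries over when a chlorine or a methoxy group replaces the methyl.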